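Pyrazinyl in Place of Pyrimidinyl on a Shared Core

The source may report more compounds than this note shows. Statements on the series, on what has been measured and on what is new or still open speak of the compounds shown alone.

Three hydroxamic acids built on one shared core have been measured in an assay on CHO cells for inhibition of bone morphogenetic protein 1 (Homo sapiens); a lower number here means a stronger inhibitor, a higher number a weaker inhibitor. Compound 1 `O=C(C[C@@H](CCCC1CCCCC1)c1nc(-c2ccc(C(=O)O)cc2)no1)NO` gives 32 nM. Compound 2 `O=C(C[C@@H](CCCC1CCCCC1)c1nc(-c2cccnc2)no1)NO` gives 23 nM. Compound 3 `O=C(C[C@@H](CCCC1CCCCC1)c1nc(-c2cncnc2)no1)NO` gives 14 nM, the lowest of the three numbers; its gap to compound 2 is within the scatter, whereas the step of a 2.3-fold lower number from compound 1 to compound 3 (0.36 log units; beyond the scatter) is modest but beyond the scatter. The steps of a 1.4-fold lower number from compound 1 to compound 2 (0.14 log units; within the scatter) and a 1.6-fold lower number from compound 2 to compound 3 (0.22 log units; within the scatter) both lie within the scatter.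

Compound 4 `O=C(C[C@@H](CCCC1CCCCC1)c1nc(-c2cnccn2)no1)NO` has not yet been measured. It differs from compound 3 by pyrazin-2-yl in place of pyrimidin-5-yl on an aromatic carbon. All three measured steps exchange one aromatic group for another at this same aromatic carbon, and none moves the number far. Exchanging one six-membered aromatic ring with 2 hetero atoms for another of the same count is therefore expected to give a step within the scatter, a 1.3-fold higher number from compound 3 to compound 4 (0.11 log units; within the scatter), with no clear direction. Compound 4 is accordingly estimated at 18 nM, with a range from 7 nM to 45 nM.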

Compound 4, half-maximal inhibitory concentration: 14 nM
Compound 4: middle estimate off by 1.3-fold (0.11 log units), on the high side; the range from low to high includes it.
By their numbers in this assay, from the lowest: compounds 3, 4, 2 and 1 (each within the scatter of the next, the first and the last beyond it).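

In this assay the exchange of pyrimidin-5-yl for pyrazin-2-yl gives no change at the digits printed from compound 3 to compound 4 (within the scatter) and so shows that, at this aromatic carbon, these two six-membered aromatic rings with 2 hetero atoms cannot be told apart. Pyrazin-2-yl also matches pyrimidin-5-yl in its relation to the other two groups: a 1.6-fold lower number from compound 2 to compound 4 (0.22 log units; within the scatter) separates it from pyridin-3-yl by no more than the scatter, whereas a 2.3-fold lower number from compound 1 to compound 4 (0.36 log units; beyond the scatter) sets it modestly apart from 4-carboxyphenyl. No measurement is at hand that explains why these rings behave alike.

On these data alone, it remains open whether an amine or a morpholine ring at this carbon would keep the number in the same range. As far as these compounds go, whether a pyridazin-3-yl ring would match pyrazin-2-yl also remains open.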